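The compounds below may be only part of what the source reports. "The series", "measured", "known", "first", "only" and "open" are said of these compounds alone.

Measured in a functional assay on HT-29 cells (Homo sapiens) for antiproliferative activity, read by MTT assay, with a stated time of 72 h; a lower number here means a stronger inhibitor, a higher number a weaker inhibitor:

compound 1 `O=C(Nc1ccc(Oc2ccnc3[nH]ccc23)c(F)c1)c1cc2cccnc2n(-c2ccccc2)c1=O`, compound 1 gives 160 nM
compound 2 `Cn1ccc2c(Oc3ccc(NC(=O)c4cc5cccnc5n(-c5ccc(Br)cc5)c4=O)cc3)ccnc21`, compound 2 gives 690 nM
compound 3 `Cn1ccc2c(Oc3ccc(NC(=O)c4cc5cccnc5n(-c5ccccc5)c4=O)cc3F)ccnc21`, compound 3 gives 510 nM

Compound 3 stands second highest of the three numbers in this assay. Its nearest neighbour is compound 2, and the two values lie within the scatter of each other; compound 1 lies furthest away, with a clearly lower number. The one single-point step among these compounds is a 3.2-fold higher number from compound 1 to compound 3 (0.50 log units; beyond the scatter), which shows methyl on the aromatic nitrogen costing a modest amount of potency.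

The step now followed goes from compound 3 to compound 4 `Cn1ccc2c(Oc3ccc(NC(=O)c4cc5cccnc5n(-c5ccc(Br)cc5)c4=O)cc3F)ccnc21`: bromo in place of hydrogen on an aromatic carbon. For the measured compounds named here, no measured step isolates this change. Compound 2 carries the same bromo, but it differs from both compound 1 and compound 3 in two places, so only the bare values can be compared: compound 2 sits close to compound 3 and well above compound 1. Taken together with the methyl step, the values of compound 1 and compound 2 leave little room for a large effect of bromo on its own. The expectation for this assay is therefore a step of a 1.2-fold higher number from compound 3 to compound 4 (0.07 log units; within the scatter), within the scatter. Compound 4 is estimated at 600 nM, with a range of 250 nM to 1500 nM.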

Compound 4, half-maximal inhibitory concentration: 330 nM
Beside the measured number, compound 4's estimate is 1.8-fold (0.26 log units) above it; the range from low to high includes it.
By their numbers in this assay, from the lowest: compound 1; then compounds 4, 3 and 2 (each within the scatter of the next, the first and the last beyond it).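

In this assay, for the compounds shown here, the phenyl to 4-bromophenyl change is now read directly, on an aromatic carbon para to a large group, and it gives a 1.5-fold lower number from compound 3 to compound 4 (0.19 log units; within the scatter) in a series where this change had no isolated step, so bromo at this position is tolerated in this background. The same compound also gives the first reading of fluoro in the presence of the 4-bromophenyl group, with a 2.1-fold lower number from compound 2 to compound 4 (0.32 log units; beyond the scatter) as a modest step that stands clear of the scatter and is larger than anything the bromo change can be shown to do here. No measurement at hand explains either step.

Going by these compounds, both readings rest on a single pair each and on the methylated aromatic nitrogen, so it remains open whether bromo behaves the same way with hydrogen on that nitrogen, as in compound 1. It is also open how a methoxy group, an amine or a carboxylic acid at the same place on the phenyl ring would compare with bromo, since bromo is the only replacement for hydrogen shown there.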